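Benzoyl ester of a cyclopropyl-bearing hydroxymethyl quinone

The source may report more compounds than this note shows. Statements on the series, on what has been measured and on what is new or still open speak of the compounds shown alone.

Measured compounds:
compound 1 `COC1=CC(=O)c2c(c(CO)cn2C)C1=O` with 220000 nM
compound 2 `COC1=CC(=O)c2c(c(CO)c(C3CC3)n2C)C1=O` with 540000 nM
compound 3 `COC1=CC(=O)c2c(c(COC(=O)c3ccccc3F)cn2C)C1=O` with 500 nM

In a functional assay on V79-379A cells (Cricetulus griseus) for cytotoxicity, read by MTT assay, in the presence of a further agent that is not named here (on this read-out lower numbers stand for stronger inhibition and higher numbers for weaker inhibition), compound 2 gives the highest of the three numbers. Its nearest neighbour is compound 1, from which it is separated by a 2.5-fold higher number from compound 1 to compound 2 (0.39 log units; beyond the scatter); the furthest is compound 3, which gives a far lower number. Compound 4 `COC1=CC(=O)c2c(c(COC(=O)c3ccccc3)c(C3CC3)n2C)C1=O` is not yet measured and differs from compound 2 in one place: benzoyl in place of hydrogen on an oxygen on a saturated carbon.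

Within the data shown here, no step between measured compounds follows exactly this change. Among the measured compounds shown here, the only measured step, from compound 1 to compound 2, concerns the cyclopropyl and not the ester, and it is modest. What bears on the ester is the pair of compound 1 and compound 3: compound 1 gives 220000 nM, whereas compound 3, which carries a fluorobenzoyl ester on the same oxygen, gives 500 nM. That pair shows a very large drop in the number once the hydroxy becomes an aroyl ester. Compound 4 is therefore expected to show a large step downward, a 450-fold lower number from compound 2 to compound 4 (2.65 log units; beyond the scatter), rather than none beyond the scatter. For compound 4 the estimate in this assay is 1200 nM, with a range from 250 nM to 6000 nM.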

Compound 4, half-maximal inhibitory concentration: 198000 nM
Compound 4: the middle estimate sits 170-fold (2.22 log units) below what was measured, outside the stated range (above it).
By their numbers in this assay, from the lowest: compound 3; then compounds 4 and 1 (each within the scatter of the next); then compound 2.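

In this assay, benzoyl in place of hydrogen on the oxygen of the cyclopropyl-bearing compound gives only a modest change, a 2.7-fold lower number from compound 2 to compound 4 (0.44 log units; beyond the scatter), though it lies beyond the scatter. The earlier compounds showed an aroyl ester only on a core without cyclopropyl, where compound 1 gives (220000 nM) and compound 3, its fluorobenzoyl ester, gives (500 nM), so the new result shows that an ester on this oxygen does not bring so large a drop on every core shown. Nothing measured here beyond these numbers speaks to why the two esters stand so far apart.

Compound 3 and compound 4 differ in two places, the fluorine on the benzoyl and the cyclopropyl, so the compounds shown leave open which of the two accounts for the gap between them, and the plain benzoyl ester without cyclopropyl would separate the two. As far as these compounds go, it also stays open whether an acetyl ester or a carbamate on the same oxygen, or a methyl or a longer alkyl chain in place of the cyclopropyl, would follow compound 3 or compound 4.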